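Swapping the aminophenyl for a difluorophenyl on the carbonyl

A few compounds are considered here, and "the series" means these few. Any claim that something is new, unique, unknown or untested is made for them only; others in the source may bear on it.

Compound 1 `COc1cc(-c2cc(/C=C/C(=O)c3ccc(N)cc3)[nH]n2)cc(OC)c1OC` gives -93% in a functional assay on SF-539 cells (Homo sapiens) for cytotoxicity, read by sulforhodamine B assay, with a stated time of 48 h, tested at 10 uM; on this read-out lower numbers stand for a stronger effect and higher numbers for a weaker effect at the one concentration tested. Compound 2 `COc1ccc(C(=O)/C=C/c2cc(-c3cc(OC)c(OC)c(OC)c3)n[nH]2)cc1OC`, which carries a 3,4-dimethoxyphenyl on the carbonyl carbon, gives -94%, so the two measured compounds sit within the scatter of each other; that change is a number 1 percentage points lower from compound 1 to compound 2 (within the scatter). Compound 3 `COc1cc(-c2cc(/C=C/C(=O)c3ccc(F)c(F)c3)[nH]n2)cc(OC)c1OC` is not yet measured. It differs from compound 1 as follows: 3,4-difluorophenyl in place of 4-aminophenyl on a carbonyl carbon. Among the compounds with values here, the one measured step, which also exchanges the ring on the carbonyl carbon, left the read-out unchanged, so no step beyond the scatter is expected here, with a number 5 percentage points higher from compound 1 to compound 3 (within the scatter). Compound 3 is therefore estimated at -88%, between -100% and -55%.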

Compound 3, a percentage reported as activity, at one concentration (the size of the read-out at that concentration, not a potency): 21%
Compound 3: middle estimate off by 109 percentage points, on the low side, and the stated range ends below it.
By their numbers in this assay, from the lowest: compounds 2 and 1 (each within the scatter of the next); then compound 3.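

In this assay the 3,4-difluorophenyl group gives a number 114 percentage points higher from compound 1 to compound 3 (beyond the scatter) and a number 115 percentage points higher from compound 2 to compound 3 (beyond the scatter) on the same exchange at the carbonyl carbon. The 4-aminophenyl and 3,4-dimethoxyphenyl compounds had looked alike, but this position does not accept every aromatic ring: the strong effect is lost with the 3,4-difluorophenyl group. No measurement here accounts for that loss. The compounds shown leave open whether the fluorines themselves drive the change, and whether a plain phenyl ring or a ring bearing a hydroxyl group on the carbonyl carbon would keep the strong effect.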